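The compounds below may be only part of what the source reports. "The series", "measured", "known", "first", "only" and "open" are said of these compounds alone.

Of the compounds shown here, three sharing one core have been measured so far in a functional assay on MCF-10A cells (Homo sapiens) for antiproliferative activity, with a stated time of 48 h (a lower number here means that less compound is needed, a higher number that more compound is needed for the effect), and they differ only in the group on a saturated chain carbon bound to a nitrogen on an aromatic ring. Compound 1 `COc1ccc2nc(C)cc(NCc3cccnc3)c2c1` gives 44800 nM, compound 2 `COc1ccc2nc(C)cc(NCc3ccc(C)cc3)c2c1` gives 18800 nM and compound 3 `COc1ccc2nc(C)cc(NCC3CCCN(C)C3)c2c1` gives 6400 nM. Compound 2 therefore stands in the middle of the three.

Compound 4 `COc1ccc2nc(C)cc(NCc3ccc(C(F)(F)F)cc3)c2c1` departs from compound 2 at one place, on an aromatic carbon of a six-membered aromatic ring of carbon only, para to a large group: trifluoromethyl in place of methyl on an aromatic carbon. In words, this is trifluoromethyl in place of methyl on an aromatic carbon.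

For the measured compounds named here, no measured step tests this exchange directly. The nearest evidence comes from replacing the whole group on the chain carbon: a 2.4-fold lower number from compound 1 to compound 2 (0.38 log units; beyond the scatter), a 2.9-fold lower number from compound 2 to compound 3 (0.47 log units; beyond the scatter) and a 7.0-fold lower number from compound 1 to compound 3 (0.85 log units; beyond the scatter). All three are modest, and each exchanges a complete ring group, whereas compound 4 keeps the ring of compound 2 and alters only its substituent. A smaller step is therefore expected in this assay, with none beyond the scatter and no firm direction. The expected change is a 1.2-fold lower number from compound 2 to compound 4 (0.07 log units; within the scatter). For compound 4 the estimate is 16000 nM, with an expected range from 6500 nM to 40000 nM.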

Compound 4, half-maximal effective concentration: 7600 nM
The estimate for compound 4 lay 2.1-fold (0.32 log units) above the measured number; the measured number falls inside the stated range.
By their numbers in this assay, from the lowest: compounds 3 and 4 (each within the scatter of the next); then compound 2; then compound 1.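

In this assay, the substituent on this ring is not a silent place: trifluoromethyl in place of methyl, on an aromatic carbon para to a large group, gives a 2.5-fold lower number from compound 2 to compound 4 (0.39 log units; beyond the scatter) while the rest of compound 2 stays unchanged. This single-substituent exchange carries the same modest grade as an exchange of the complete ring group, a 2.4-fold lower number from compound 1 to compound 2 (0.38 log units; beyond the scatter), so changes smaller than a whole ring group can also move the number beyond the scatter. Compound 4 gives 7600 nM and compound 3 gives 6400 nM, values within the scatter of each other, so in this series a 1-methylpiperidin-3-yl group is not needed to reach that level. No measurement at hand speaks to the origin of the step.

Whether the step is particular to trifluoromethyl remains open, since the compounds shown do not include a chlorine, methoxy or nitrile group at this place. Also open, on these data alone, is whether the same exchange would carry over to the pyridin-3-yl ring of compound 1.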